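Halogen Swap at an Aromatic Carbon: Chloro to Fluoro

The source may report more compounds than this note shows. Statements on the series, on what has been measured and on what is new or still open speak of the compounds shown alone.

Measured so far:
compound 1, `NS(=O)(=O)c1ccc(N2N=C(c3ccc(OCc4ccccc4)cc3)CC2c2ccc(F)cc2)cc1`: 60000 nM
compound 2, `NS(=O)(=O)c1ccc(N2N=C(c3ccc(OCc4ccccc4)cc3)CC2c2ccccc2Cl)cc1`: 12000 nM

In an ADME assay on BHK-21 cells (Mesocricetus auratus) for cytotoxicity, read by MTT assay, with a stated time of 72 h (a lower number here means that less compound is tolerated, a higher number that more compound is tolerated), compound 2 holds the lower of the two numbers, with compound 1 standing above it by a 5.0-fold lower number from compound 1 to compound 2 (0.70 log units; beyond the scatter). That single step changes both the halogen and its place at once, so it bears only loosely on the present change. Compound 3, `NS(=O)(=O)c1ccc(N2N=C(c3ccc(OCc4ccccc4)cc3)CC2c2ccccc2F)cc1`, differs from compound 2 by fluoro in place of chloro on an aromatic carbon. Among the compounds with values here, with no measured step isolating this swap, only a small shift is expected, likely within the scatter. Compound 3 is therefore estimated at 20000 nM, within 8000 nM to 50000 nM. This expected step is a 1.7-fold higher number from compound 2 to compound 3 (0.22 log units; within the scatter).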

Compound 3, half-maximal cytotoxic concentration: 90000 nM
The estimate for compound 3 lay 4.5-fold (0.65 log units) below the measured number, and the stated range ends below it.
By their numbers in this assay, from the lowest: compound 2; then compounds 1 and 3 (each within the scatter of the next).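

In this assay, fluoro in place of chloro on this aromatic carbon gives a 7.5-fold higher number from compound 2 to compound 3 (0.88 log units; beyond the scatter), so with the place held fixed, the halogen alone moves the number beyond the scatter. Set against this, 2-fluorophenyl in place of 4-fluorophenyl gives a 1.5-fold higher number from compound 1 to compound 3 (0.18 log units; within the scatter), so the low number in this set stands with the chloro rather than with the place of the halogen. Nothing measured here gives a reason for the difference between the two halogens.

From the compounds shown here alone, whether a bromo, methyl or methoxy group on the same carbon would stand with the chloro or the fluoro remains open. So does whether 4-chlorophenyl would keep the lower number of the 2-chlorophenyl compound.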